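This account rests on a few compounds, and the source may have more. Where it says the series, first, only, none or still open, it means among the compounds named here.

Series notes, cytotoxicity. The shared core of compound 1 `CCOC(=O)CCCCCOc1cccc(CN(C(=O)c2ccc(-c3ccncc3)cc2)C(C)C)c1` carries a pyridin-4-yl on an aromatic carbon. In an ADME assay on BJ cells (Homo sapiens) for cytotoxicity, read by CellTiter-Glo and resazurin assay, with a stated time of 72 h (on this read-out lower numbers stand for an effect already at smaller amounts and higher numbers for an effect only at larger amounts of compound), compound 1 gives only a limit, > 26000 nM. Compound 2 `CCOC(=O)CCCCCOc1cccc(CN(C(=O)c2ccc(-c3cccc(-c4ccccc4)c3)cc2)C(C)C)c1` carries 3-phenylphenyl in place of pyridin-4-yl on an aromatic carbon; in this assay compound 2 likewise gives only a limit, > 26000 nM. Compound 3 `CCOC(=O)CCCCCOc1cccc(CN(C(=O)c2ccc(-c3cccc(OC)c3)cc2)C(C)C)c1` carries 3-methoxyphenyl in place of pyridin-4-yl on an aromatic carbon; in this assay compound 3 gives only a limit, > 21000 nM. Compound 3 thus stands at the limit of > 21000 nM in this assay, at which 1 of the 3 values shown sits, while compounds 1 and 2 stand at the limit of > 26000 nM in this assay, at which 2 of the 3 values shown sit; none of the three gives a number. The steps a step that the two limits leave unreadable from compound 1 to compound 2, a step that the two limits leave unreadable from compound 1 to compound 3 and a step that the two limits leave unreadable from compound 2 to compound 3 remain unreadable in size. Compound 4 `CCOC(=O)CCCCCOc1cccc(CN(C(=O)c2ccc(-c3cccc(C(F)(F)F)c3)cc2)C(C)C)c1` differs from compound 3 by trifluoromethyl in place of methoxy on an aromatic carbon. Among the compounds with values here, no measured step bears directly on this change, and the three measured changes of the aromatic substituent all ended at a limit. Compound 4 is therefore expected to give a limit again, the step that the limit leaves unreadable from compound 3 to compound 4 being expected to stay within the scatter. The estimate for compound 4 in this assay is 26000 nM, with a range from 12000 nM to 60000 nM.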

Compound 4, half-maximal effective concentration: < 1.3 nM
Compound 4: a limit, no number (the forecaster's own chance of this, stated with the estimate: 85%); middle value at least 20000-fold (4.30 log units) from the limit.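

In this assay, within the data shown here, trifluoromethyl in place of methoxy on this aromatic carbon gives an at least 16000-fold lower number from compound 3 to compound 4 (4.20 log units; beyond the scatter), the first step whose size can be read, since all earlier steps cannot be read. The outcome at this position therefore depends strongly on the group carried there, as the 3-(trifluoromethyl)phenyl compound also shows in an at least 20000-fold lower number from compound 2 to compound 4 (4.30 log units; beyond the scatter) and in an at least 20000-fold lower number from compound 1 to compound 4 (4.30 log units; beyond the scatter). All three steps are minimum sizes, as compound 4 gives a limit and not a number: the limit of < 1.3 nM in this assay, at which 1 of the 4 values shown sits.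

The compounds shown leave open whether the low number is specific to trifluoromethyl or is shared by chlorine or a nitrile on the same aromatic carbon. They also leave open whether it persists with a carboxylic acid in place of the ethyl ester.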